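This account rests on a few compounds, and the source may have more. Where it says the series, first, only, none or still open, it means among the compounds named here.

In an ADME assay for solubility, in simulated intestinal fluid (a lower number here means a less soluble compound, a higher number a more soluble compound), two compounds sharing the same core have been measured so far. Compound 1 `O=C(Cc1ccc2c(c1)B(O)OC2)NS(=O)(=O)c1ccccc1` gives 900 ug/mL and compound 2 `O=C(O)c1ccc2c(c1)B(O)OC2` gives 950 ug/mL, so the two stand within the scatter of each other. The next compound, compound 3 `O=C(O)CCc1ccc2c(c1)B(O)OC2`, departs from compound 2 in one place, with 2-carboxyethyl in place of carboxy on an aromatic carbon. The acid group is kept in name, but it now stands at the end of a chain. Going by the values given here, no measured step shows what an exchange of this kind does in this assay, and that leaves the expectation on thin ground. It can only start from compound 2 at 950 ug/mL. A small fall is expected, but none beyond the scatter. The estimated change is a 1.2-fold lower number from compound 2 to compound 3 (0.07 log units; within the scatter). For compound 3 the expected value is 800 ug/mL, with an estimated range from 400 ug/mL to 1300 ug/mL.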

Compound 3, solubility: > 1000 ug/mL
Compound 3 was reported as a limit; the forecaster's own chance of this, stated with the estimate: 10%; middle value at least 1.2-fold (0.09 log units) from the limit.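

In this assay compound 3 is reported only as a limit, > 1000 ug/mL, and not as a number. Going by these compounds alone, this gives the first step that can be read at this position, on an aromatic carbon meta to a fused ring and para to a fused ring: exchanging carboxy for 2-carboxyethyl gives an at least 1.0-fold higher number from compound 2 to compound 3 (0.02 log units; that floor lies within the scatter). The earlier compounds shown here offered no such step, and this one shows that the acid group can stand at the end of this chain with no sign of a loss in the reading, though the floor alone cannot separate the two compounds. How far the true value of compound 3 lies past the floor cannot be told from this reading, which sits at the ceiling of what is reported: the limit of > 1000 ug/mL in this assay, at which 1 of the 3 values shown sits.

The compounds shown leave open what an amine, a primary amide or a simple methyl group would do on this aromatic carbon, with no carboxylic acid present there. They also leave open whether a longer chain ending in a carboxylic acid would stay at the same limit or fall to a reading that can be given as a number.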